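Methyl for cyano on selenium: an expected gain in potency

A few compounds are considered here, and "the series" means these few. Any claim that something is new, unique, unknown or untested is made for them only; others in the source may bear on it.

Of the compounds shown here, three have been measured in a functional assay on A549 cells (Homo sapiens) for inhibition, read by MTT assay, with a stated time of 48 h; on this read-out higher numbers stand for weaker inhibition and lower numbers for stronger inhibition. Compound 1 `COc1ccc(N(C)c2nc(C)nc3ccccc23)cc1[Se]C` gives 11 nM, and compound 3 `COc1ccc(N(C)c2nc(C)nc3ccccc23)cc1[Se]C#N` gives 49 nM. Compound 2 `Cc1nc(N(C)c2ccc([Se]C#N)c(Cl)c2)c2ccccc2n1` gives 7 nM, the lowest of the three numbers; its gap to compound 1 lies within the scatter, so those two cannot be ordered, while its gap to compound 3 lies beyond it.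

Compound 1 and compound 3 differ in a single place: methyl in place of cyano on a selenium. That change produced a 4.5-fold lower number from compound 3 to compound 1 (0.65 log units; beyond the scatter), a modest step that is beyond the scatter.

Compound 4 `C[Se]c1ccc(N(C)c2nc(C)nc3ccccc23)cc1Cl` has not yet been measured. It relates to compound 2 exactly as compound 1 relates to compound 3, since (methyl in place of cyano on a selenium). How the core of compound 2 differs from the core of compound 3 is not broken down here, but the place of the change is the same in both pairs, so the same change is made. The expectation rests on that one earlier step: compound 4 is expected to give a lower number than compound 2 because the identical change gave a 4.5-fold lower number from compound 3 to compound 1 (0.65 log units; beyond the scatter). In this assay compound 4 is estimated at 3 nM, most likely between 1 nM and 10 nM. This estimate corresponds to an expected step of a 2.3-fold lower number from compound 2 to compound 4 (0.37 log units; beyond the scatter), held somewhat smaller than the measured one since a single example is a thin basis.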

Compound 4, half-maximal inhibitory concentration: 2 nM
The estimate for compound 4 lay 1.5-fold (0.18 log units) above the measured number; the range from low to high includes it.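

Putting methyl in place of cyano on the selenium again lowered the number in this assay, with a 3.5-fold lower number from compound 2 to compound 4 (0.54 log units; beyond the scatter), so the change that helped on the core of compound 3 also helped on the core of compound 2. The size of the gain also held up, as the two steps cannot be told apart: the same change on two cores in this assay, a 4.5-fold lower number (0.65 log units; beyond the scatter) from compound 3 to compound 1 and a 3.5-fold lower number (0.54 log units; beyond the scatter) from compound 2 to compound 4, 1.3-fold (0.10 log units) apart, within the scatter of two such steps. This shows that, on these two cores, the change behaves in much the same way, but two examples do not establish a rule for other cores in the series, and the numbers alone do not explain why methyl gives the lower number.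

The compounds shown leave open what other groups on the selenium would do, such as ethyl, a longer chain or a chain ending in an amine. They also leave open whether replacing the selenium itself with sulfur would keep these low numbers.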